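The source may hold more compounds than are shown below. What is called first, only, known or untested is meant among the compounds shown, and "the series" means these compounds.

Working notes on the series.

Of the compounds shown here, three have numbers so far in an assay on isolated protein for inhibition of cathepsin S (Homo sapiens); on this read-out lower numbers stand for stronger inhibition and higher numbers for weaker inhibition. Compound 1 `CC1CCC(C[C@H](CC(=O)N2CCOCC2)C(=O)N[C@]2(C#N)CCN(C3CCCCC3)C2)CC1` gives 14 nM. Compound 2 `N#CC1(NC(=O)[C@@H](CC(=O)N2CCOCC2)CC2CCCCC2)CC1`, built on a different core, gives 135 nM. Compound 3 `N#C[C@@]1(NC(=O)[C@@H](CC(=O)N2CCOCC2)CC2CCCCC2)CCN(C2CCCCCC2)C1` gives 23 nM, which is the second highest of the three numbers; its nearest neighbour is compound 1, whose number is lower by an amount within the scatter, and the furthest is compound 2, whose number is higher by an amount beyond the scatter. Going by the values given here, no pair among the measured compounds differs in only one place, so no measured single step is available.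

Compound 4 `CN1CC[C@@](C#N)(NC(=O)[C@@H](CC(=O)N2CCOCC2)CC2CCCCC2)C1` has not yet been measured in this assay. Relative to compound 3 the change is methyl in place of cycloheptyl on an amine nitrogen in a ring. Because compound 3 gives 23 nM while compound 2, which carries no amine in a ring at all, gives 135 nM, the expectation is that taking away the cycloheptyl and leaving only methyl on the amine nitrogen in the ring moves the number upward, toward weaker inhibition, by a step beyond the scatter but short of the gap to compound 2. The step from compound 3 to compound 4 is expected to be a 3.0-fold higher number from compound 3 to compound 4 (0.48 log units; beyond the scatter). For compound 4 the estimated value in this assay is 70 nM, with a range from 25 nM to 200 nM.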

Compound 4, half-maximal inhibitory concentration: 155 nM
Compound 4: middle estimate off by 2.2-fold (0.35 log units), on the low side, within the range that was stated.
By their numbers in this assay, from the lowest: compounds 1 and 3 (each within the scatter of the next); then compounds 2 and 4 (each within the scatter of the next).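

In this assay methyl in place of cycloheptyl on an amine nitrogen in a ring gives a 6.7-fold higher number from compound 3 to compound 4 (0.83 log units; beyond the scatter) and so marks this nitrogen as a position where the choice of group matters, with a step beyond the scatter for this one change. The second step, 3-cyano-1-methylpyrrolidin-3-yl in place of 1-cyanocyclopropyl on an amide-type nitrogen, gives a 1.1-fold higher number from compound 2 to compound 4 (0.06 log units; within the scatter) and lies within the scatter, so with only methyl on its ring nitrogen the core of compound 4 cannot be told apart from the 1-cyanocyclopropyl of compound 2 in this assay. Nothing at hand accounts for either step.

The compounds shown leave open how the number runs between methyl and cycloheptyl on this nitrogen, for instance with an ethyl, an isopropyl or a cyclopentyl group there, and whether a carbon ring is needed at all or an open chain such as n-hexyl would serve equally. Also open, from the compounds shown here alone, is how a group holding oxygen, such as tetrahydropyranyl or an acetyl, would behave on the same nitrogen.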